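Fluoro added to a chlorophenyl sulfonamide of unchanged core

This account rests on a few compounds, and the source may have more. Where it says the series, first, only, none or still open, it means among the compounds named here.

Compound 1 `Cc1cc(C)c(S(=O)(=O)NC2=NCCN2C(=S)SN2CCn3c2nsc3=S)c(C)c1`: in a functional assay on KYSE-510 cells (Homo sapiens) for antiproliferative activity, read by crystal violet staining, with a stated time of 96 h (on this read-out higher numbers stand for weaker inhibition of growth and lower numbers for stronger inhibition of growth), compound 1 gives >= 20000 nM, a limit of the assay.
Compound 2 `COc1ccc(OC)c(S(=O)(=O)NC2=NCCN2C(=S)SN2CCn3c2nsc3=S)c1`: in this assay compound 2 gives >= 20000 nM, a limit of the assay.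
Compound 3 `O=S(=O)(NC1=NCCN1C(=S)SN1CCn2c1nsc2=S)c1cccc(Cl)c1`: in this assay compound 3 gives >= 20000 nM, a limit of the assay.

Compound 3 therefore stands at the limit, not at a number. Compound 4 `O=S(=O)(NC1=NCCN1C(=S)SN1CCn2c1nsc2=S)c1ccc(F)c(Cl)c1` differs from it by fluoro in place of hydrogen on an aromatic carbon. The measured steps a step that the two limits leave unreadable from compound 1 to compound 2, a step that the two limits leave unreadable from compound 1 to compound 3 and a step that the two limits leave unreadable from compound 2 to compound 3 are all unreadable because of the limit of >= 20000 nM in this assay, at which 3 of the 3 values shown sit. Within the data shown here, no measured step shows the effect of a change on the aryl group, so no step beyond the scatter is expected in this assay from the fluoro. Compound 4 is expected to give 30000 nM, between 10000 nM and 100000 nM, most likely again a limit, which is the estimated step that the limit leaves unreadable from compound 3 to compound 4.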

Compound 4, concentration for 50% growth inhibition: >= 20000 nM
Compound 4 ended at the assay's limit; the forecaster's own chance of this, stated with the estimate: 85%; the middle value does not contradict the limit.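

Compound 3 and compound 4 both sit at a limit rather than at a number, so no step to compound 4 can be read: the limit of >= 20000 nM in this assay, at which 4 of the 4 values shown sit.

The compounds shown leave open which aryl group on the shared core, if any, would give a measurable number in this assay.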